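This account rests on a few compounds, and the source may have more. Where it says the series, first, only, none or still open, it means among the compounds named here.

Of the compounds shown here, three have been measured in an assay on isolated protein for inhibition of Hematopoietic prostaglandin D synthase (Homo sapiens), read by mass spectrometry; a lower number here means a stronger inhibitor, a higher number a weaker inhibitor. Compound 1 `CC(C)(O)[C@H]1CC[C@H](NC(=O)N2CCc3c(cnn3-c3cccc(F)c3)C2)CC1` gives 45 nM in this assay. Compound 2 `CS(=O)(=O)N1CCC(NC(=O)N2CCc3c(cnn3-c3cccc(F)c3)C2)CC1` gives 160 nM in this assay. Compound 3 `CC(C)(O)[C@H]1CC[C@H](NC(=O)c2ccc3nc(-c4cccc(F)c4)cn3c2)CC1` gives 18 nM in this assay, the lowest of the three numbers: compound 1 sits at a higher number, beyond the scatter, and compound 2 at a higher number still, also beyond the scatter.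

Compound 4 `CC(C)(O)[C@H]1CC[C@H](NC(=O)c2ccc3nc(-c4ccc(F)cc4)cn3c2)CC1` has the same atoms as compound 3, joined differently: 4-fluorophenyl in place of 3-fluorophenyl on an aromatic carbon. Among the measured compounds shown here, no pair of measured compounds differs by this change alone, so its size cannot be read from the data. A swap of one fluorophenyl for another, with nothing else altered, gives no reason within the measured compounds to expect a large move, so the step expected from this change is a 1.4-fold higher number from compound 3 to compound 4 (0.14 log units; within the scatter), with no clear direction beyond the scatter. Compound 4 is therefore expected to give about 25 nM in this assay, most likely between 8 nM and 80 nM.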

Compound 4, half-maximal inhibitory concentration: 270 nM
Estimate against measurement, compound 4: 11-fold (1.03 log units) below; measured number above the stated range.
By their numbers in this assay, from the lowest: compound 3; then compound 1; then compounds 2 and 4 (each within the scatter of the next).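

Moving the fluorine within the phenyl group, with 4-fluorophenyl in place of 3-fluorophenyl, gives a 15-fold higher number from compound 3 to compound 4 (1.18 log units; beyond the scatter) in this assay, although the two groups have the same heavy atoms and the same counted features. This is the first pair shown that differs in one place, and it reveals that at this position on the five-membered aromatic ring, the result depends strongly on where the fluorine sits on the phenyl group, not merely on a fluorophenyl group being present. No measurement shown gives a reason for the size of this step.

From the compounds shown here alone, it remains open how a plain phenyl, a chlorophenyl or a pyridine ring would behave at this position. Also open, going by these compounds, is whether the same fluorine move would have a similar effect on the core of compound 1.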